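Methoxy for nitro: expected shift in agonist potency

The source may report more compounds than this note shows. Statements on the series, on what has been measured and on what is new or still open speak of the compounds shown alone.

Compound 1 `CC(C)(C)OC(=O)CN(Cc1ccc(Cl)cc1)Cc1nc2ccccc2s1` has "not determined" (no result reported) in a functional assay on HEK293 cells for agonist activity at nuclear receptor subfamily 1 group D member 1 (Homo sapiens), read by a luciferase reporter, with a stated time of 24 h; on this read-out lower numbers stand for an effect already at smaller amounts and higher numbers for an effect only at larger amounts of compound. Going by the values given here, compound 2 `CC(C)(C)OC(=O)CN(Cc1ccc([N+](=O)[O-])cc1)Cc1ccc([N+](=O)[O-])s1` gives 2500 nM in this assay, the only number in the set, so it stands alone and nothing can be ranked against it. Compound 3 `COc1ccc(CN(CC(=O)OC(C)(C)C)Cc2ccc([N+](=O)[O-])s2)cc1` is yet to be measured and differs from compound 2 in one place: methoxy in place of nitro on an aromatic carbon, with everything else kept. Among the compounds with values here, no step between two measured compounds exists, so the size of such a change in this assay has no precedent in these notes. The expectation is a shift that stays within the scatter or reaches only a little beyond it, if anything toward larger amounts of compound. Compound 3 is expected near 3500 nM in this assay, within a range of 1000 nM to 12000 nM. The step this estimate implies is expected to be a 1.4-fold higher number from compound 2 to compound 3 (0.15 log units; within the scatter).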

Compound 3, half-maximal effective concentration: 2900 nM
Compound 3: the middle estimate sits 1.2-fold (0.08 log units) above what was measured; the range from low to high includes it.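

In this assay, going by these compounds alone, the first step that can be read at this position is a 1.2-fold higher number from compound 2 to compound 3 (0.06 log units; within the scatter), for methoxy in place of nitro on an aromatic carbon, para to a large group. The 4-nitrophenyl and 4-methoxyphenyl compounds cannot be told apart on this read-out, so this position accepts either group with no difference beyond the scatter. Nothing available bears on why these two groups read alike.

On these data alone, whether an amine or a carboxylic acid at the same place would also read alike remains open, and so does the part played by the nitro group that compound 2 and compound 3 both keep on the other ring. As far as these compounds go, compound 1, with "not determined" (no result reported), adds no comparison, so the reach of this result beyond compound 2 and compound 3 is unknown.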